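A few compounds are considered here, and "the series" means these few. Any claim that something is new, unique, unknown or untested is made for them only; others in the source may bear on it.

Measured in a functional assay on HT-29 cells (Homo sapiens) for cytotoxicity, read by MTT assay, with a stated time of 72 h; a lower number here means a stronger inhibitor, a higher number a weaker inhibitor:
compound 1, `COc1cccc(-c2cc(C(=O)Nc3ccc(Oc4ccnc5cc(OCCCN6CCCCC6)c(OC)cc45)c(F)c3)c3ccccc3n2)c1`: 1740 nM
compound 2, `COc1cc2c(Oc3ccc(NC(=O)c4cc(-c5cccc(Cl)c5)nc5ccccc45)cc3F)ccnc2cc1OCCCN1CCCCC1`: 62 nM
compound 3, `COc1cc2c(Oc3ccc(NC(=O)c4cc(-c5cccc(Cl)c5)nc5ccc(F)cc45)cc3F)ccnc2cc1OCCCN1CCC(C)CC1`: 92 nM

One single-point change has already been measured within this set. Going from compound 2 to compound 1 the change is methoxy in place of chloro on an aromatic carbon, and in this assay that step is a 28-fold higher number from compound 2 to compound 1 (1.45 log units; beyond the scatter). Compound 3 and compound 2 differ in more than one place; the difference between the two cores is not broken down here. In this assay compound 3 sits close to compound 2, the gap between them lying within the scatter, and well apart from compound 1.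

Compound 4, `COc1cccc(-c2cc(C(=O)Nc3ccc(Oc4ccnc5cc(OCCCN6CCC(C)CC6)c(OC)cc45)c(F)c3)c3cc(F)ccc3n2)c1`, has not yet been measured in this assay. It relates to compound 3 as compound 1 relates to compound 2: the change is methoxy in place of chloro on an aromatic carbon, the same change, with the place described in identical terms in both pairs. For the measured compounds named here, the only guide to its size is that single measured instance, so the expectation rests on one step alone; whether the core of compound 3 carries the change in the same way is not known from these data. Going by the values given here, the expected step in this assay is a 22-fold higher number from compound 3 to compound 4 (1.34 log units; beyond the scatter), of similar size to the earlier one because a 28-fold higher number from compound 2 to compound 1 (1.45 log units; beyond the scatter) is the sole measured precedent. For compound 4 the estimate in this assay is 2000 nM, with a likely range from 700 nM to 6000 nM.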

Compound 4, half-maximal inhibitory concentration: 1210 nM
For compound 4 the middle estimate is 1.7-fold (0.22 log units) above the measured one; the range from low to high includes it.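

In this assay, methoxy in place of chloro on the aromatic carbon gives a 13-fold higher number from compound 3 to compound 4 (1.12 log units; beyond the scatter), and the gap between this step and the earlier one on the other core is no larger than repeat measurement could produce: the same change on two cores in this assay, a 28-fold higher number (1.45 log units; beyond the scatter) from compound 2 to compound 1 and a 13-fold higher number (1.12 log units; beyond the scatter) from compound 3 to compound 4, 2.1-fold (0.33 log units) apart, within the scatter of two such steps

On these two cores, then, the change from 3-chlorophenyl to 3-methoxyphenyl carries over as a large step in the same direction, and its size on one core was a fair guide to its size on the other. This does not show that the step is independent of the core in general: the two cores differ from each other in more than one place, only two instances exist, and neither pair says which feature of the structures produces the step or whether another core would carry it in the same way.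

On these data alone, it remains open whether the higher number is particular to methoxy or follows from removing chloro, which would need other groups on that same aromatic carbon, such as a nitrile, an amine or a longer chain like ethoxy. As far as these compounds go, it also remains open whether the step would keep its size if only one of the differences between the two cores were present.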